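The source may report more compounds than this note shows. Statements on the series, on what has been measured and on what is new or still open speak of the compounds shown alone.

Measured compounds:
- Compound 1, `NC(=O)c1c(NC(=O)c2ccccc2Cl)sc2c1CCN(Cc1ccccc1Cl)C2`, gives 4430 nM in a functional assay on MKN-74 cells (Homo sapiens) for antiproliferative activity, with a stated time of 24 h; on this read-out higher numbers stand for weaker inhibition and lower numbers for stronger inhibition.
- Compound 2, `NC(=O)c1c(NC(=O)c2ccccc2Cl)sc2c1CCN(Cc1ccc(Cl)cc1Cl)C2`, gives 16300 nM in this assay.
- Compound 3, `NC(=O)c1c(NC(=O)c2ccccc2Cl)sc2c1CCN(Cc1cc(Cl)cc(Cl)c1)C2`, gives 23700 nM in this assay.

Compound 3 carries the highest number of the three, though the step of a 1.5-fold higher number from compound 2 to compound 3 (0.16 log units; within the scatter) lies within the scatter, so compound 2 and compound 3 cannot be told apart; only against compound 1 does compound 3 stand clearly apart, the step of a 5.3-fold higher number from compound 1 to compound 3 (0.73 log units; beyond the scatter) being beyond the scatter. The step of a 3.7-fold higher number from compound 1 to compound 2 (0.57 log units; beyond the scatter) likewise shows that changes on the benzyl ring move the number in this set.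

Compound 4, `Cc1ccccc1NC(=S)N1CCc2c(sc(NC(=O)c3ccccc3Cl)c2C(N)=O)C1`, differs from compound 3 by a group of 10 heavy atoms (8 carbon, 1 nitrogen, 1 sulfur; one six-membered aromatic ring of carbon only) in place of a group of 9 heavy atoms (7 carbon, 2 chlorine; one six-membered aromatic ring of carbon only), on an amine nitrogen in a ring. Within the data shown here, none of the measured steps covers a change of this kind: all three concern chlorine on the benzyl ring, and their sizes, from within the scatter up to modest, give only a sense of how far such changes reach. A change that removes the benzyl altogether falls outside what they show, so the direction is open and the uncertainty wide.

Compound 4 is therefore expected to give about 12000 nM, between 2500 nM and 60000 nM. The expected step is a 2.0-fold lower number from compound 3 to compound 4 (0.30 log units; within the scatter), an estimate rather than a measurement.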

Compound 4, half-maximal inhibitory concentration: 11700 nM
The estimate for compound 4 lay 1.0-fold (0.01 log units) above the measured number; low and high end bracket the measured number.
By their numbers in this assay, from the lowest: compound 1; then compounds 4, 2 and 3 (each within the scatter of the next, the first and the last beyond it).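

Compound 4 shows that in this assay the amine nitrogen in the ring can carry a group other than a chlorinated benzyl and still give a number in the range of the benzyl compounds: a 2.0-fold lower number from compound 3 to compound 4 (0.31 log units; beyond the scatter) is a modest step beyond the scatter, while a 1.4-fold lower number from compound 2 to compound 4 (0.14 log units; within the scatter) is within it, so these two compounds cannot be told apart. The new group, with its hydrogen-bond donor and acceptor, does not match compound 1, as a 2.6-fold higher number from compound 1 to compound 4 (0.42 log units; beyond the scatter) lies beyond the scatter. Nothing given here accounts for these differences.

The compounds shown leave open how a plain acetyl group, a longer alkyl chain or an aminoethyl chain would behave on that nitrogen. They also leave open whether the methyl on the aromatic ring of compound 4 contributes to its number.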